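Taking the fluoro group off compound 3

The source may hold more compounds than are shown below. What is called first, only, known or untested is meant among the compounds shown, and "the series" means these compounds.

compound 1 `COC(=O)/C(=C/c1ccccc1)CN1C(=O)[C@@H](OC)[C@H]1c1cccc(Cl)c1` measured at 25100 nM 
compound 2 `COC(=O)/C(=C/c1ccccc1)CN1C(=O)[C@@H](OC)[C@H]1c1ccc(OC)cc1` measured at 11600 nM 
compound 3 `COC(=O)/C(=C/c1ccccc1)CN1C(=O)[C@@H](OC)[C@H]1c1cccc(F)c1` measured at 13700 nM 

In a functional assay on MCF7 cells (Homo sapiens) for antiproliferative activity, read by MTT assay, with a stated time of 48 h (a higher number here means a weaker inhibitor, a lower number a stronger inhibitor), compound 3 at 13700 nM stands second highest of the three numbers. Among the compounds with values here, compound 4 `COC(=O)/C(=C/c1ccccc1)CN1C(=O)[C@@H](OC)[C@H]1c1ccccc1` has hydrogen in place of fluoro on an aromatic carbon as its only change. The closest measured change, fluoro in place of chloro, is a 1.8-fold lower number from compound 1 to compound 3 (0.26 log units; within the scatter) and stays small. Within the data shown here, replacing 4-methoxyphenyl with 3-fluorophenyl gives a 1.2-fold higher number from compound 2 to compound 3 (0.07 log units; within the scatter) and is also small, while a 2.2-fold lower number from compound 1 to compound 2 (0.34 log units; beyond the scatter) is the one modest step. No step beyond the scatter is therefore expected, and the estimate is a 1.1-fold higher number from compound 3 to compound 4 (0.04 log units; within the scatter) for this change. Compound 4 is expected at 15000 nM with an estimated range from 7000 nM to 32000 nM overall.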

Compound 4, half-maximal inhibitory concentration: 12900 nM
For compound 4 the middle estimate is 1.2-fold (0.07 log units) above the measured one, and the stated range covers the measured number.
By their numbers in this assay, from the lowest: compounds 2, 4, 3 and 1 (each within the scatter of the next, the first and the last beyond it).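

In this assay, the unsubstituted phenyl ring of compound 4 shows that the activity seen so far does not depend on a substituent on this aromatic ring. Replacing fluoro with hydrogen gives a 1.1-fold lower number from compound 3 to compound 4 (0.03 log units; within the scatter), replacing methoxy with hydrogen gives a 1.1-fold higher number from compound 2 to compound 4 (0.05 log units; within the scatter), and replacing chloro with hydrogen gives a 1.9-fold lower number from compound 1 to compound 4 (0.29 log units; within the scatter). All three steps lie within the scatter, so fluoro, methoxy and chloro show no measurable gain or loss against hydrogen. As far as these compounds go, whether an amine or a carboxylic acid on this ring would shift the number beyond the scatter remains open. Nothing available explains these small steps.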